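The source may report more compounds than this note shows. Statements on the series, on what has been measured and on what is new or still open speak of the compounds shown alone.

Measured so far:
- Compound 1 `CCCCCCc1cn([C@@H]2O[C@H](CO)[C@@H](O)[C@H]2O)nn1`: > 200000 nM
- Compound 2 `COc1ccc(-c2cn([C@@H]3O[C@H](CO)[C@@H](O)[C@H]3O)nn2)cc1`: 73000 nM

In a functional assay on CCRF-CEM cells (Homo sapiens) (a higher number here means a weaker inhibitor, a lower number a stronger inhibitor), compound 1 stands only at a limit and not at a number, > 200000 nM. Compound 2 gives a true number, 73000 nM. Compound 3 `OC[C@H]1O[C@@H](n2cc(-c3ccsc3)nn2)[C@H](O)[C@@H]1O` carries thiophen-3-yl in place of hexyl on an aromatic carbon. A modest step toward stronger inhibition is expected, an at least 1.6-fold lower number from compound 1 to compound 3 (0.22 log units; that floor lies within the scatter). This expectation rests on compound 2, which also has an aromatic ring in that place and reads 73000 nM. For compound 3 the estimated value is 120000 nM, with an expected range of 40000 nM to 300000 nM.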

Compound 3, half-maximal inhibitory concentration: 139000 nM
Compound 3: middle estimate off by 1.2-fold (0.06 log units), on the low side, and the stated range covers the measured number.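

In this assay, thiophen-3-yl in place of hexyl on the aromatic carbon gives an at least 1.4-fold lower number from compound 1 to compound 3 (0.15 log units; that floor lies within the scatter). Within the data shown here, this is the first step readable at this position, and it shows that a five-membered aromatic ring here also gives a true number: compound 3 reads 139000 nM. The full size of the step stays unknown because compound 1 stands only at a limit: the limit of > 200000 nM in this assay, at which 1 of the 3 values shown sits.

On these data alone, whether the real step exceeds the scatter remains open. So does how an amine, a carboxylic acid or a longer chain would read on this carbon.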